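The source may report more compounds than this note shows. Statements on the series, on what has been measured and on what is new or still open speak of the compounds shown alone.

Measured compounds:
Compound 1, `CCOc1ccc(NC(=O)c2c(N)n[nH]c2NC)cc1`: in a functional assay on PANC-1 cells (Homo sapiens) for cytotoxicity, read by resazurin assay, with a stated time of 48 h (a lower number here means a stronger inhibitor, a higher number a weaker inhibitor), compound 1 gives 31000 nM.
Compound 2, `CCOc1ccc(-n2nnc3n[nH]c(NC)c3c2=O)cc1`: in this assay compound 2 gives 9920 nM.
Compound 3, `C=CCN/C(SC)=C(/C#N)C(=O)Nc1ccc(OCC)cc1`: in this assay compound 3 gives 21800 nM.

Compound 1 carries the highest number of the three. Compound 3 sits within the usual scatter of it, so the two cannot be ordered; compound 2 lies beyond the scatter, at a lower number. Compound 4, `CCOc1ccc(NC(=O)c2c(N)n[nH]c2Nc2ccccc2)cc1`, has not been measured. It differs from compound 1 by phenyl in place of methyl on a nitrogen on an aromatic ring. For the measured compounds named here, no measured pair shows this same change, so there is nothing to gauge it against. A modest step of a 1.6-fold lower number from compound 1 to compound 4 (0.19 log units; within the scatter) toward a lower number is expected, though it may well fall within the scatter. Compound 4 is therefore estimated at 20000 nM, within a range from 6000 nM to 60000 nM.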

Compound 4, half-maximal inhibitory concentration: 21000 nM
The estimate for compound 4 lay 1.1-fold (0.02 log units) below the measured number; the measured number falls inside the stated range.
By their numbers in this assay, from the lowest: compound 2; then compounds 4, 3 and 1 (each within the scatter of the next).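

For the compounds shown here, at this position, on a nitrogen on an aromatic ring, the first measured step in this assay reads a 1.5-fold lower number from compound 1 to compound 4 (0.17 log units; within the scatter), so compound 1 and compound 4 cannot be told apart. Phenyl, with its six-membered aromatic ring and 6 heavy atoms, thus gives a number indistinguishable from that given by methyl, with 1 heavy atom, in this single pair. No available evidence bears on this result.

On these data alone, whether a butyl chain, a benzyl group or a chlorophenyl group on this nitrogen would give a number beyond the scatter remains open. So does whether methylamino to anilino would read the same on the core of compound 2.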